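The compounds below may be only part of what the source reports. "The series", "measured", "known", "first", "only" and "open" are said of these compounds alone.

Compound 1 `O[C@@H]1[C@@H](OCc2ccccc2)[C@H](OCc2ccccc2)[C@@H](COCc2ccccc2)O[C@@H]1CC1CCCCC1` was tested in a functional assay on HL-60 cells (Homo sapiens) for antiproliferative activity, read by MTT assay (on this read-out lower numbers stand for stronger inhibition and higher numbers for weaker inhibition), and gave 17200 nM, the lowest of the two numbers recorded so far. Compound 2 `O[C@@H]1[C@@H](OCc2ccccc2)[C@H](O)[C@@H](COCc2ccccc2)O[C@H]1Cc1ccccc1` gave 35300 nM in this assay, a higher number than compound 1 by more than the usual scatter. Compound 3 `O[C@H]1CO[C@H](COCc2ccccc2)[C@@H](OCc2ccccc2)[C@@H]1OCc1ccccc1` differs from compound 1 by hydrogen in place of cyclohexylmethyl on a saturated ring carbon. Going by the values given here, no step of this kind has yet been measured, so the expectation rests on the two values alone: a moderate weakening, beyond the scatter but not large, is expected from compound 1 to compound 3 a 2.3-fold higher number from compound 1 to compound 3 (0.37 log units; beyond the scatter). Compound 3 is thus estimated to give about 40000 nM, within a range from 14000 nM to 120000 nM.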

Compound 3, half-maximal inhibitory concentration: "not active" (no number reported)
Compound 3 has no reported number here; there is nothing to compare the estimate with.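

In this assay, going by these compounds alone, compound 3 was reported as not active, without a number, so no step from compound 1 can be read. No available evidence bears on this result. The compounds shown leave open how much the cyclohexylmethyl group contributes to the activity of compound 1.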